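The source may report more compounds than this note shows. Statements on the series, on what has been measured and on what is new or still open speak of the compounds shown alone.

The work concerns a small set of compounds built on a shared core and tested in a functional assay on FOCUS cells (Homo sapiens) for inhibition, read by sulforhodamine B assay, with a stated time of 72 h; a lower number here means a stronger inhibitor, a higher number a weaker inhibitor. Compound 1 `Cc1ccc(C2=Nn3c(nnc3C(C)c3ccc(CC(C)C)cc3)SC2)cc1` and compound 2 `COc1ccc(C2=Nn3c(nnc3C(C)c3ccc(-c4ccccc4)c(F)c3)SC2)cc1` are the two members with a numerical result. In this assay compound 2 gives 4400 nM, and compound 1 gives 6800 nM; the two numbers lie within the usual scatter of each other, so neither can be set above the other. Compound 3 `COc1ccc2cc(C(C)c3n[nH]c(=S)n3N)ccc2c1`, which lacks the fused bicyclic portion of the core, is reported in this assay only as "not active" (no number reported), without a number.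

The step under consideration leads from compound 2 to compound 4 `CC(c1ccc(-c2ccccc2)c(F)c1)c1nnc2n1N=C(c1ccc([N+](=O)[O-])cc1)CS2`. The change is nitro in place of methoxy on an aromatic carbon, in words a nitro in place of methoxy on an aromatic carbon; cut one bond further out, it reads 4-methoxyphenyl to 4-nitrophenyl. Going by the values given here, no measured pair in this set shows the effect of such an exchange, so there is no step on which to lean. The expectation for compound 4 is therefore cautious: a step from compound 2 to compound 4 of a 1.1-fold lower number from compound 2 to compound 4 (0.04 log units; within the scatter), which is expected to stay within the scatter rather than point clearly in either direction. On that basis compound 4 is estimated at 4000 nM, with a range from 1500 nM to 12000 nM in this assay.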

Compound 4, half-maximal inhibitory concentration: 3500 nM
Beside the measured number, compound 4's estimate is 1.1-fold (0.06 log units) above it; low and high end bracket the measured number.
By their numbers in this assay, from the lowest: compounds 4, 2 and 1 (each within the scatter of the next).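

In this assay, going by these compounds alone, the exchange of methoxy for nitro on an aromatic carbon, para to a large group, gives the first step that can be read at this position: a 1.3-fold lower number from compound 2 to compound 4 (0.10 log units; within the scatter). Methoxy and nitro differ in their atoms and in their counts of hydrogen-bond acceptors, yet compound 2 and compound 4 cannot be told apart by their numbers, so this exchange leaves the result in this assay within what repeated measurements would show. No measurement in hand bears on this result or offers an explanation for it.

From the compounds shown here alone, it remains open whether any group at this position can carry the number beyond the scatter in either direction, and an amine, a carboxylic acid or a longer alkoxy chain in place of the nitro would speak to that. Going by these compounds, it also remains open whether the same exchange would read alike with the other part of the molecule as it stands in compound 1, since this single step rests on one background only.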